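Sulfonate Versus Sulfonamide Linkers in Chloropropylurea Cytotoxins

The source may hold more compounds than are shown below. What is called first, only, known or untested is meant among the compounds shown, and "the series" means these compounds.

Compound 1 `CCc1ccccc1OS(=O)(=O)c1ccc(NC(=O)NCCCCl)cc1` and compound 2 `CCCc1ccccc1OS(=O)(=O)c1ccc(NC(=O)NCCCCl)cc1` share one core, compound 2 carrying (methyl in place of hydrogen on a saturated chain carbon, two bonds along the chain from an aromatic carbon). In a functional assay on M21 cells (Homo sapiens) for cytotoxicity, read by sulforhodamine B assay, with a stated time of 48 h (on this read-out lower numbers stand for stronger inhibition and higher numbers for weaker inhibition), compound 1 gives 15000 nM, and compound 2 gives 13000 nM, so that a 1.2-fold lower number from compound 1 to compound 2 (0.06 log units; within the scatter). Compound 3 `Cc1ccccc1NS(=O)(=O)c1ccc(NC(=O)NCCCCl)cc1` rests on a different core, and how the two cores differ is not broken down here. In this assay compound 3 reaches only a limit of the assay, > 200000 nM. Compound 4 `CCc1ccccc1NS(=O)(=O)c1ccc(NC(=O)NCCCCl)cc1` differs from compound 3 by methyl in place of hydrogen on a saturated chain carbon bound to an aromatic carbon. This is the same kind of change as that from compound 1 to compound 2, though there it sat two bonds along the chain from an aromatic carbon, whereas here the carbon is bound to an aromatic carbon. Compound 4 is expected to give about 250000 nM in this assay, between 100000 nM and 600000 nM. This estimate means a step that the limit leaves unreadable from compound 3 to compound 4. It rests on compound 3 sitting at the limit of > 200000 nM in this assay, at which 1 of the 3 values shown sits, and on the step of a 1.2-fold lower number from compound 1 to compound 2 (0.06 log units; within the scatter).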

Compound 4, half-maximal inhibitory concentration: > 200000 nM
Compound 4: no number, only a limit; the forecaster's own chance of this, stated with the estimate: 70%; the middle value is on the limit's open side.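

Going by these compounds alone, compound 3 and compound 4 both rest on a limit in this assay, so no step between them can be read: the limit of > 200000 nM in this assay, at which 2 of the 4 values shown sit. The compounds shown leave open whether changing 2-methylphenyl to 2-ethylphenyl alters cytotoxicity on this core at all.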